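Methylated pyrazole on the fused core: expecting weaker agonism

The compounds below may be only part of what the source reports. "The series", "measured", "known", "first", "only" and "open" are said of these compounds alone.

Compound 1 `Cn1ccc(-c2cccc3c2CCC3c2ncc[nH]2)n1`: > 1300 nM
Compound 2 `c1cc(-c2ccn[nH]2)c2c(c1)C(c1ncc[nH]1)CC2`: 52 nM
Compound 3 `c1cc(-c2ncco2)c2c(c1)C(c1ncc[nH]1)CC2`: 170 nM

Three compounds share a core and differ only in the five-membered ring on an aromatic carbon. In a functional assay on CHO cells for agonist activity at Alpha-1A adrenergic receptor (Homo sapiens), read by FLIPR and calcium flux (on this read-out lower numbers stand for an effect already at smaller amounts and higher numbers for an effect only at larger amounts of compound), compound 1 gives only a limit, > 1300 nM, and no number. Compound 2 gives 52 nM in this assay, and compound 3 gives 170 nM. Among the two numbers shown, compound 3 stands highest; its nearest neighbour is compound 2, with a 3.3-fold higher number from compound 2 to compound 3 (0.51 log units; beyond the scatter). The third value is a limit (the limit of > 1300 nM in this assay, at which 1 of the 3 values shown sits).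

Compound 4 `Cn1nccc1-c1cccc2c1CCC2c1ncc[nH]1` is not yet measured. It differs from compound 3 as follows: 1-methyl-1H-pyrazol-5-yl in place of 1,3-oxazol-2-yl on an aromatic carbon. Among the measured compounds shown here, two measured steps bear on this. The step of an at least 7.6-fold lower number from compound 1 to compound 3 (0.88 log units; beyond the scatter) shows that replacing a methylated pyrazole by the oxazole lowered the number markedly; the step of a 3.3-fold higher number from compound 2 to compound 3 (0.51 log units; beyond the scatter) shows that the unmethylated pyrazole gave a lower number than the oxazole. Compound 4 carries a methylated pyrazole, as compound 1 does, so the account expects the reverse of the first step: a higher number than compound 3, likely by a large margin. For compound 4 the expected step is a 4.7-fold higher number from compound 3 to compound 4 (0.67 log units; beyond the scatter). The estimate for compound 4 is 800 nM, with a range from 250 nM to 3000 nM.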

Compound 4, half-maximal effective concentration: 278 nM
Estimate against measurement, compound 4: 2.9-fold (0.46 log units) above; low and high end bracket the measured number.
By their numbers in this assay, from the lowest: compound 2; then compounds 3 and 4 (each within the scatter of the next). At a limit, above all of these: compound 1.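

In this assay, a methylated pyrazole does not by itself give a number as high as the one for the first methylated isomer: the move from 1-methyl-1H-pyrazol-3-yl to 1-methyl-1H-pyrazol-5-yl gives an at least 4.6-fold lower number from compound 1 to compound 4 (0.66 log units; beyond the scatter), so the way the ring is attached matters as well as the methyl. Methyl in place of hydrogen on an aromatic nitrogen still gives a 5.3-fold higher number from compound 2 to compound 4 (0.73 log units; beyond the scatter), whereas the exchange for 1,3-oxazol-2-yl gives a 1.6-fold higher number from compound 3 to compound 4 (0.21 log units; within the scatter), which leaves those two groups indistinguishable here. The first of these steps has no fixed size, as compound 1 is a limit and not a number: the limit of > 1300 nM in this assay, at which 1 of the 4 values shown sits.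

The compounds shown leave open how an ethyl group or a longer chain on that ring nitrogen would read in this assay. They also leave open whether an amine or a carboxylic acid on the ring would be tolerated at this place.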